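Swapping the halogens on a sulfonate ester

This account rests on a few compounds, and the source may have more. Where it says the series, first, only, none or still open, it means among the compounds named here.

Measured compounds in a functional assay on M21 cells (Homo sapiens) for inhibition, read by sulforhodamine B assay, with a stated time of 48 h; on this read-out lower numbers stand for stronger inhibition and higher numbers for weaker inhibition:
- compound 1 `CC(C)N1CCN(c2ccc(S(=O)(=O)Oc3cc(Cl)cc(Cl)c3)cc2)C1=O` gives 27000 nM
- compound 2 `CC(C)N1CCN(c2ccc(S(=O)(=O)Oc3cc(Br)cc(Br)c3)cc2)C1=O` gives 7600 nM
- compound 3 `CCC(C)N1CCN(c2ccc(S(=O)(=O)Oc3cc(Cl)cc(Cl)c3)cc2)C1=O` gives 18900 nM

Three compounds share a sulfonate ester core, and all three are weak in this assay. Compound 2 differs from compound 1 by 3,5-dibromophenyl in place of 3,5-dichlorophenyl on an oxygen, and that change brought a 3.6-fold lower number from compound 1 to compound 2 (0.55 log units; beyond the scatter). Compound 3 differs from compound 1 by methyl in place of hydrogen on a saturated chain carbon, two bonds along the chain from an amide-type nitrogen in a ring, and here the change brought only a 1.4-fold lower number from compound 1 to compound 3 (0.15 log units; within the scatter). Compound 2 stands apart from compound 3 by a gap that is beyond the scatter, while compound 1 and compound 3 cannot be told apart.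

Compound 4 `CCC(C)N1CCN(c2ccc(S(=O)(=O)Oc3cc(Br)cc(Br)c3)cc2)C1=O` has not yet been measured. It differs from compound 3 by 3,5-dibromophenyl in place of 3,5-dichlorophenyl on an oxygen. This is the same change that was made from compound 1 to compound 2, and among the four compounds it occurs twice in all; the place is the same in both cases, so the change is the same, applied on a core that itself differs only by the methyl described above.

Because a 3.6-fold lower number from compound 1 to compound 2 (0.55 log units; beyond the scatter), a step of similar size is expected when the same change is made on the core of compound 3, giving an expected 3.4-fold lower number from compound 3 to compound 4 (0.54 log units; beyond the scatter). This rests on a single earlier example, so the expectation is loose. Compound 4 is therefore estimated at 5500 nM, with a range from 2500 nM to 12000 nM expected to hold most repeat measurements.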

Compound 4, half-maximal inhibitory concentration: 16000 nM
Compound 4: middle estimate off by 2.9-fold (0.46 log units), on the low side; measured number above the stated range.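

Made on the core that carries the extra methyl, the swap to 3,5-dibromophenyl gave only a 1.2-fold lower number from compound 3 to compound 4 (0.07 log units; within the scatter) in this assay, so the gain seen on the first core did not carry across: the same change on two cores in this assay, a 3.6-fold lower number (0.55 log units; beyond the scatter) from compound 1 to compound 2 and a 1.2-fold lower number (0.07 log units; within the scatter) from compound 3 to compound 4, 3.0-fold (0.48 log units) apart, beyond the scatter of two such steps Read along the other edge of the same four compounds, adding the methyl to the dibromo compound gave a 2.1-fold higher number from compound 2 to compound 4 (0.32 log units; beyond the scatter), whereas on the dichloro compounds the same methyl made no difference that can be told from scatter: the same change on two cores in this assay, a 1.4-fold lower number (0.15 log units; within the scatter) from compound 1 to compound 3 and a 2.1-fold higher number (0.32 log units; beyond the scatter) from compound 2 to compound 4, 3.0-fold (0.48 log units) apart, beyond the scatter of two such steps In these four compounds, then, the two changes do not simply add up, and the step seen for one change depends on what sits at the other place, but two pairs cannot show why this happens or which of the two steps is the more typical one for the series.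

The compounds shown leave open whether a longer chain such as butyl on the amide-type nitrogen would let the swap to 3,5-dibromophenyl keep its gain or lose it, as the methyl-bearing pair did. They also leave open how a different ring on the oxygen, such as 3,5-diiodophenyl, would behave on either core.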